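A few compounds are considered here, and "the series" means these few. Any claim that something is new, unique, unknown or untested is made for them only; others in the source may bear on it.

Measured compounds:
compound 1 `OC(CCn1nc2c(Br)c(Br)c(Br)c(Br)c2n1)c1cccc(Cl)c1` — 0%
compound 2 `OC(CCn1nc2c(Br)c(Br)c(Br)c(Br)c2n1)c1ccc(Br)cc1` — 0%

In a functional assay on CCRF-CEM cells (Homo sapiens) for antiproliferative activity, read by MTT assay, with a stated time of 48 h, tested at 100 uM (on this read-out lower numbers stand for a stronger effect and higher numbers for a weaker effect at the one concentration tested), compound 1 gives 0%. In this assay compound 2 gives 0%, so compound 2 stands level with compound 1 at the digits shown; the step of no change at the digits printed from compound 1 to compound 2 (within the scatter) stays within the scatter. Compound 3 `CC(O)CCn1nc2c(Br)c(Br)c(Br)c(Br)c2n1` has not been measured in this assay. It differs from compound 2 by methyl in place of 4-bromophenyl on a saturated chain carbon bound to an oxygen on a saturated carbon and a saturated chain carbon. Within the data shown here, the only measured step, from compound 1 to compound 2, swaps one aryl group for another at this same chain carbon and brings no change, so compound 3 has nothing directly comparable: the aryl group is replaced by methyl, a smaller change in the same place than any measured. Since both measured compounds show no effect, compound 3 is expected to stay at the same level, with the step of no change at the digits printed from compound 2 to compound 3 (within the scatter) expected to lie within the scatter. The estimate for compound 3 in this assay is 0%, in the range 0% to 15%.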

Compound 3, a percentage reported as activity, at one concentration (the size of the read-out at that concentration, not a potency): 0%
The estimate for compound 3 equals the measured number at the digits printed, and the stated range covers the measured number.
By their numbers in this assay, from the lowest: compounds 1, 2 and 3 (each within the scatter of the next).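

In this assay, methyl in place of 4-bromophenyl gives no change at the digits printed from compound 2 to compound 3 (within the scatter) and methyl in place of 3-chlorophenyl gives no change at the digits printed from compound 1 to compound 3 (within the scatter) on this saturated chain carbon. The earlier step only exchanged one aryl group for another, whereas these steps remove the aromatic ring from this place altogether, and the read-out at the one concentration tested stays level, so across these three compounds an aromatic ring at this carbon makes no difference that can be read. Nothing available here offers an explanation for this flat result.

The compounds shown leave open whether an amine, a carboxylic acid or a longer chain at this carbon would move the read-out away from this level. They also leave open what replacing the hydroxyl group on the chain, or changing the shared core, would do.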